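The compounds below may be only part of what the source reports. "The series", "measured", "known", "first", "only" and "open" are said of these compounds alone.

Measured so far:
- compound 1, `N#C/C=C\[C@H]1O[C@@H](n2cnc3c(N)ncnc32)[C@H](O)[C@@H]1O`: 100 ug/mL
- compound 2, `N#C/C=C/[C@H]1O[C@@H](n2cnc3c(N)ncnc32)[C@H](O)[C@@H]1O`: >= 20 ug/mL

In a functional assay on HEL cells (Homo sapiens) for cytotoxicity (on this read-out higher numbers stand for lower toxicity in this test and lower numbers for higher toxicity in this test), compound 1 gives 100 ug/mL. For compound 2 the same this assay reports only a limit, >= 20 ug/mL. The step that the limit leaves unreadable from compound 1 to compound 2 is therefore not readable in size; the limit of >= 20 ug/mL in this assay, at which 1 of the 2 values shown sits, is what hides it, and the fact that compounds 1 and 2 differ only in the configuration as drawn is the whole of the structural difference between these two. Compound 3, `N#C/C(Cl)=C\[C@H]1O[C@@H](n2cnc3c(N)ncnc32)[C@H](O)[C@@H]1O`, is the next candidate, and its change from compound 2 is a group of 5 heavy atoms (3 carbon, 1 nitrogen, 1 chlorine; no ring) in place of a group of 4 heavy atoms (3 carbon, 1 nitrogen; no ring), on a saturated ring carbon. Among the measured compounds shown here, no measured step covers a change of this kind: the only step in hand, from compound 1 to compound 2, concerns configuration alone and its size is unknown. No shift beyond the scatter is therefore expected, a step that the limit leaves unreadable from compound 2 to compound 3. For compound 3 the expected value in this assay is 50 ug/mL, with a range from 15 ug/mL to 150 ug/mL.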

Compound 3, minimum cytotoxic concentration: 100 ug/mL
Beside the measured number, compound 3's estimate is 2.0-fold (0.30 log units) below it, within the range that was stated.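

In this assay, putting the chlorine-bearing group in place of the 2-cyanoethenyl group on the saturated ring carbon gives no change at the digits printed from compound 1 to compound 3 (within the scatter). Among the compounds shown here, this is the first pair where a change of group, and not of configuration alone, can be read at this position, and on this read-out the added chlorine leaves the value within the scatter. Compound 2 has only a limit, >= 20 ug/mL, so the steps that touch it cannot be read.

Open, on these data alone, is how a bromine, a methyl group, an amine or a carboxylic acid in the chlorine's place would read in this assay. Also open, as far as these compounds go, is whether a longer chain on the same ring carbon would stay within the scatter of compound 1.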